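The source may report more compounds than this note shows. Statements on the series, on what has been measured and on what is new or still open speak of the compounds shown alone.

Of the compounds shown here, two of this small set have been measured. Compound 1 `ClCc1ccccc1Cn1cnc2c(Cl)nc(Cl)nc21` carries two chloro groups on its core and gives 3310 nM in a functional assay on NCI-H460 cells (Homo sapiens) for cytotoxicity, read by sulforhodamine B assay, with a stated time of 48 h; a higher number here means a weaker inhibitor of growth, a lower number a stronger inhibitor of growth. Compound 2 `ClCc1ccc(Cn2cnc3ncnc(Cl)c32)cc1` carries one chloro group on a related core; in this assay compound 2 gives 1770 nM. These two values sit within the usual scatter of each other, so neither compound can be called the stronger inhibitor of growth on this evidence.

Compound 3 `ClCc1ccc(Cn2cnc3nc(Cl)nc(Cl)c32)cc1` has not yet been measured. It differs from compound 2 in one place: chloro in place of hydrogen on an aromatic carbon. Going by the values given here, no measured pair shows this same change, so the direction of the step is uncertain. Given that compound 1, which also carries two chloro groups, gives 3310 nM, the step of a 1.4-fold higher number from compound 2 to compound 3 (0.15 log units; within the scatter) is expected to be small, if anything toward a weaker inhibitor, and not clearly beyond the scatter. Compound 3 is therefore estimated at 2500 nM, with a range from 1000 nM to 6000 nM.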

Compound 3, concentration for 50% growth inhibition: 15500 nM
Compound 3: the middle estimate sits 6.2-fold (0.79 log units) below what was measured, outside the stated range (above it).
By their numbers in this assay, from the lowest: compounds 2 and 1 (each within the scatter of the next); then compound 3.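

Placing a chloro group on the aromatic carbon between two ring nitrogen atoms is not a neutral change in this assay: it gives an 8.8-fold higher number from compound 2 to compound 3 (0.94 log units; beyond the scatter) and so makes a weaker inhibitor of growth, with a step beyond the scatter. Going by these compounds alone, no earlier pair differed in just one place, so this is the first sign that this single position, on a ring that already carries a chloro group, can clearly move the number on its own. Nothing measured here offers an explanation for this step.

On these data alone, whether this result belongs to chloro in particular or to any group at this position stays open. An amine or a methoxy group on the same carbon would help to separate these two possibilities.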